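Methyl on the five-membered ring of compound 1

The compounds below may be only part of what the source reports. "The series", "measured", "known", "first", "only" and "open" are said of these compounds alone.

compound 1 `CCCc1nnc(O)n2c(C)ncc12` — > 48000 nM
compound 2 `Cc1ncc2cnnc(O)n12` — > 48000 nM
compound 3 `COCc1nc(Br)c2c(Br)nnc(O)n12` — > 48000 nM

In a functional assay for inhibition, with Homo sapiens as the target (a higher number here means a weaker inhibitor, a lower number a stronger inhibitor), compound 1 gives > 48000 nM, which is a limit of the assay and not a number. Compound 2 likewise gives only a limit, > 48000 nM. Compound 3 also gives a limit, > 48000 nM. The whole measured set therefore sits on (the limit of > 48000 nM in this assay, at which 3 of the 3 values shown sit), and compound 1 has no number of its own to stand on, only this limit.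

Among the measured compounds shown here, the one measured step, a step that the two limits leave unreadable from compound 1 to compound 2, is the swap of hydrogen for propyl on an aromatic carbon; with both ends at the limit its size cannot be read.

Compound 4 `CCCc1nnc(O)n2c(C)nc(C)c12` differs from compound 1 by methyl in place of hydrogen on an aromatic carbon. Only the unreadable step from compound 1 to compound 2 bears on this change, so no direction and no size beyond the scatter can be drawn from the measured steps; the expectation is that compound 4 stays where compound 1 stands, at the limit. Compound 4 is estimated at 60000 nM in this assay, with a range from 15000 nM to 300000 nM. The expected step is a step that the limit leaves unreadable from compound 1 to compound 4, essentially none.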

Compound 4, half-maximal inhibitory concentration: > 48000 nM
Compound 4: only a limit was reported; the forecaster's own chance of this, stated with the estimate: 85%; the middle value does not contradict the limit.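

Compound 4 gives > 48000 nM in this assay, a limit of the assay and not a number. Compound 1 also has only a limit, so no new step can be read between compound 1 and compound 4. The series stays at one place: the limit of > 48000 nM in this assay, at which 4 of the 4 values shown sit.

The compounds shown leave open whether any change on the shared core gives a measurable value in this assay.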